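Adding a chloro to compound 3: working notes

The compounds below may be only part of what the source reports. "The series", "measured", "known", "first", "only" and "open" are said of these compounds alone.

Measured in a functional assay on A549 cells (Homo sapiens) for antiproliferative activity, read by MTT assay, with a stated time of 48 h; on this read-out lower numbers stand for stronger inhibition and higher numbers for weaker inhibition:
- compound 1 `Clc1cc2nc(-c3cn(-c4ccccc4)nc3-c3ccccc3)[nH]c2cc1Cl`: 11100 nM
- compound 2 `Fc1ccc(-c2nn(-c3ccccc3)cc2-c2nc3cc(Cl)c(Cl)cc3[nH]2)cc1`: 15700 nM
- compound 3 `Clc1ccc(-c2nn(-c3ccccc3)cc2-c2nc3cc(Cl)ccc3[nH]2)cc1`: 1340 nM

In this assay compound 3 gives the lowest of the three numbers, 1340 nM. Compound 4 `Clc1ccc(-c2nn(-c3ccccc3)cc2-c2nc3cc(Cl)c(Cl)cc3[nH]2)cc1` has chloro in place of hydrogen on an aromatic carbon. Going by the values given here, no measured step shows this change. Compound 1 and compound 2 already carry that chloro, and both values lie well above that of compound 3. Among the compounds with values here, the only measured step, a 1.4-fold higher number from compound 1 to compound 2 (0.15 log units; within the scatter), is a change at another place, and it suggests that compound 4 may fall near those two. A higher number is therefore expected. The expected step is a 5.2-fold higher number from compound 3 to compound 4 (0.72 log units; beyond the scatter). For compound 4 the estimated value is 7000 nM, with an expected range of 2000 nM to 18000 nM.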

Compound 4, half-maximal inhibitory concentration: 19100 nM
Compound 4: the middle estimate sits 2.7-fold (0.44 log units) below what was measured; measured number outside the range, above it.
By their numbers in this assay, from the lowest: compound 3; then compounds 1, 2 and 4 (each within the scatter of the next).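

In this assay, a second chloro on the aromatic carbon ortho to a chloro group is a large penalty (a 14-fold higher number from compound 3 to compound 4 (1.15 log units; beyond the scatter)). Once that chloro is present, the other place shows no change beyond the scatter, whether chloro replaces fluoro (a 1.2-fold higher number from compound 2 to compound 4 (0.09 log units; within the scatter)) or hydrogen (a 1.7-fold higher number from compound 1 to compound 4 (0.24 log units; within the scatter)). No measurement at hand accounts for the size of the penalty.

Open, as far as these compounds go, is whether methoxy or an amine on this carbon would fare better than chloro. Also open, from the compounds shown here alone, is whether the penalty holds with fluoro or hydrogen at the other place.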